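The source may report more compounds than this note shows. Statements on the series, on what has been measured and on what is new or still open speak of the compounds shown alone.

Compound 2 `NC1=NC2(CCSCC2)N(OCCCOc2ccc(Br)cc2)C(N)=N1` belongs to a small set of analogues that share one core and differ in the aryl group on an oxygen on a saturated carbon. In an assay on isolated protein for inhibition of Dihydrofolate reductase (Homo sapiens), read by spectrophotometry, using NADPH, with stated times of 5 s and 6 min, tested at 5 uM (on this read-out higher numbers stand for a stronger effect at the one concentration tested and lower numbers for a weaker effect), compound 2 gives > 90%, which is a limit of the read-out and not a number. Compound 3 `NC1=NC2(CCOCC2)N(OCCCOc2ccc(Br)cc2)C(N)=N1` likewise gives > 90% in this assay, again a limit. Compound 1 `NC1=NC2(CCOCC2)N(OCCCOc2cccc(Cl)c2Cl)C(N)=N1` gives 81.7% in this assay. Within the data shown here, the only measured step between compounds that differ in a single place is a number at least 8.3 percentage points higher from compound 1 to compound 3 (that floor lies within the scatter); because of the limit of > 90% in this assay, at which 2 of the 3 values shown sit, there is little room at the top of the scale for any step to show itself. Compound 4 `NC1=NC2(CCSCC2)N(OCCCOc2ccc(Cl)c(Cl)c2)C(N)=N1` differs from compound 2 by 3,4-dichlorophenyl in place of 4-bromophenyl on an oxygen on a saturated carbon. Among the measured compounds shown here, no measured step exchanges exactly this pair of aryl groups, and the nearest comparison, 2,3-dichlorophenyl against 4-bromophenyl, moved by an amount that may sit within the scatter. Compound 4 is therefore expected to remain high in this assay, with an expected step of a number at least 2 percentage points lower from compound 2 to compound 4 (that floor lies within the scatter) that stays within the scatter. The estimate for compound 4 is 88%, expected between 74% and 96%.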

Compound 4, a percentage reported as inhibition, at one concentration (the size of the read-out at that concentration, not a potency): 88.4%
Compound 4: middle estimate off by 0.4 percentage points, on the low side; the measured number falls inside the stated range.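

On the core of compound 2, the place on an oxygen on a saturated carbon also takes a 3,4-dichlorophenyl group: in this assay, replacing 4-bromophenyl gives a number at least 1.6 percentage points lower from compound 2 to compound 4 (that floor lies within the scatter). The earlier step came from the core of compound 1 and involved 2,3-dichlorophenyl, so this is the first one-place exchange shown on the core of compound 2, and 3,4-dichlorophenyl is a new pattern of halogens on the ring. The real size of the step stays unknown because one end of it is only a limit: the limit of > 90% in this assay, at which 2 of the 4 values shown sit.

From the compounds shown here alone, it remains open how this place would respond to a phenyl ring carrying an amine or a carboxylic acid rather than halogens. Also open, going by these compounds, is what a longer chain on the oxygen would do to the read-out.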